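Removing the Pentyl Chain from a Selenium-Bearing Quinazoline-Type Core

This account rests on a few compounds, and the source may have more. Where it says the series, first, only, none or still open, it means among the compounds named here.

Compound 1 `COc1ccc(CNc2nc([SeH])nc3ccccc23)cc1` gives 42700 nM in a functional assay on MCF7 cells (Homo sapiens) for cytotoxicity, read by MTT assay, with a stated time of 72 h; on this read-out higher numbers stand for weaker inhibition of growth and lower numbers for stronger inhibition of growth.
Compound 2 `Sc1nc(NCc2ccccc2)c2ccccc2n1` gives 27200 nM in this assay.
Compound 3 `CCCCC[Se]c1nc(NCc2ccccc2)c2ccccc2n1` gives 50 nM in this assay.

Compound 3 stands at the lowest number of the three: the nearest is compound 2 and the furthest is compound 1, both at higher numbers beyond the scatter. Among the measured compounds shown here, the one single-site step among the measured compounds is a 540-fold lower number from compound 2 to compound 3 (2.74 log units; beyond the scatter), where a group of 6 heavy atoms (5 carbon, 1 selenium; no ring) replaced one sulfur atom on an aromatic carbon.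

Compound 4 `[SeH]c1nc(NCc2ccccc2)c2ccccc2n1` differs from compound 3 by hydrogen in place of pentyl on a selenium. This step bears directly on the measured one in reverse: compound 3 owes its low number to a change that introduced the pentyl-bearing selenium, so taking the pentyl away is expected to undo most of that step. Compound 1, which also carries an unsubstituted selenium, sits at a high number, and compound 2 with an unsubstituted sulfur likewise. Compound 4 is therefore expected to show a large rise, a 600-fold higher number from compound 3 to compound 4 (2.78 log units; beyond the scatter), to an estimated 30000 nM, with a range from 8000 nM to 100000 nM.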

Compound 4, concentration for 50% growth inhibition: > 100000 nM
Compound 4: only a limit was reported; the forecaster's own chance of this, stated with the estimate: 10%; at least 3.3-fold (0.52 log units) between middle value and limit.
By their numbers in this assay, from the lowest: compound 3; then compounds 2 and 1 (each within the scatter of the next). At a limit, above all of these: compound 4.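

In this assay compound 4 carries only a limit of the assay, not a number: the limit of > 100000 nM in this assay, at which 1 of the 4 values shown sits. The earlier step from sulfur to pentyl on selenium joined two changes in one, and taking off the pentyl alone now gives an at least 2000-fold higher number from compound 3 to compound 4 (3.30 log units; beyond the scatter), so the low number of compound 3 is lost once the chain is gone from this selenium. Selenium without the chain does not hold that low number: one selenium atom in place of one sulfur atom gives an at least 3.6-fold higher number from compound 2 to compound 4 (0.56 log units; beyond the scatter), and hydrogen in place of methoxy on an aromatic carbon gives an at least 2.3-fold higher number from compound 1 to compound 4 (0.36 log units; beyond the scatter).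

The compounds shown leave open whether the pentyl chain would give a low number on sulfur as well, so the part played by selenium in compound 3 remains unsettled. They also leave open how the number responds to a shorter or longer chain on the selenium, or to a pentyl chain ending in an amine or a carboxylic acid.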